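Methyl on the aniline ring of a coumarin carboxamide

The source may report more compounds than this note shows. Statements on the series, on what has been measured and on what is new or still open speak of the compounds shown alone.

Two coumarin carboxamides have been tested in an assay on isolated protein for inhibition of coagulation factor XII (Homo sapiens); a lower number here means a stronger inhibitor, a higher number a weaker inhibitor. Compound 1 `Cc1cccc(NC(=O)c2cc3cc(Cl)cc(Cl)c3oc2=O)c1` gives 25000 nM in this assay, whereas compound 2 `O=C(Nc1ccccc1)c1cc2cc(Cl)cc(Br)c2oc1=O` gives 4400 nM. Compound 2 thus stands at the lower of the two numbers, and the gap to compound 1 lies beyond the scatter; the two compounds differ in more than one place, so nothing further can be read from that gap alone.

The next compound, compound 3 `Cc1cccc(NC(=O)c2cc3cc(Cl)cc(Br)c3oc2=O)c1`, is compound 2 with one change: methyl in place of hydrogen on an aromatic carbon. Among the compounds with values here, no measured pair shows this change on its own. Compound 1, which carries the same methyl, sits at the higher number, but its halogens differ as well. A modest step toward a higher number is expected, a 1.8-fold higher number from compound 2 to compound 3 (0.26 log units; within the scatter), possibly no larger than the scatter. Compound 3 is therefore estimated at 8000 nM in this assay, within a range from 2500 nM to 25000 nM.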

Compound 3, half-maximal inhibitory concentration: 10000 nM
Compound 3: the middle estimate sits 1.3-fold (0.10 log units) below what was measured; the measured number falls inside the stated range.
By their numbers in this assay, from the lowest: compound 2; then compound 3; then compound 1.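

In this assay the change from phenyl to 3-methylphenyl can now be read on its own, and the methyl gives a 2.3-fold higher number from compound 2 to compound 3 (0.36 log units; beyond the scatter) as a modest move toward weaker inhibition. Bromo in place of chloro can also be read alone for the first time, with a 2.5-fold lower number from compound 1 to compound 3 (0.40 log units; beyond the scatter) showing a modest move toward stronger inhibition, so both places on this scaffold change the number. Nothing measured here gives a reason for either step.

Going by these compounds, whether methyl would give a similar step elsewhere on that ring remains open, as does whether a carboxylic acid or an amine in its place would move the number in either direction. On these data alone, it is also open how a methoxy group would compare with the halogens on the shared core.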